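Swapping the aryl group on the triazole in compound 2

A few compounds are considered here, and "the series" means these few. Any claim that something is new, unique, unknown or untested is made for them only; others in the source may bear on it.

Measured so far:
- compound 1 `N#CC1=C(N)Oc2c(N)cc3nc4ccccc4nc3c2C12C(=O)N(Cc1cnnn1-c1ccccc1Cl)c1ccccc12`: 33500 nM
- compound 2 `CCOc1ccccc1-n1nncc1CN1C(=O)C2(C(C#N)=C(N)Oc3c(N)cc4nc5ccccc5nc4c32)c2ccccc21`: 30500 nM

In a functional assay on HepG2 cells (Homo sapiens) for antiproliferative activity, read by MTT assay, with a stated time of 48 h (a higher number here means a weaker inhibitor, a lower number a stronger inhibitor), compound 1 gives 33500 nM, and compound 2 gives 30500 nM. Compound 2 has the lowest of the two numbers, but the gap to compound 1 is small: a 1.1-fold lower number from compound 1 to compound 2 (0.04 log units; within the scatter). Within the data shown here, that single step, ethoxy in place of chloro, is the only comparison available, and it lies within the scatter.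

Compound 3 `CCc1cccc(C)c1-n1nncc1CN1C(=O)C2(C(C#N)=C(N)Oc3c(N)cc4nc5ccccc5nc4c32)c2ccccc21` differs from compound 2 in one place: 2-ethyl-6-methylphenyl in place of 2-ethoxyphenyl on an aromatic nitrogen. Among the measured compounds shown here, no measured step changes this aryl group in the way compound 3 does, so the step from compound 1 to compound 2 is the only guide, and it was within the scatter. The change from compound 2 to compound 3 is therefore expected to give no step beyond the scatter, a 1.0-fold lower number from compound 2 to compound 3 (0.01 log units; within the scatter). Compound 3 is estimated at 30000 nM in this assay, with a range from 12000 nM to 75000 nM.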

Compound 3, half-maximal inhibitory concentration: > 50000 nM
Compound 3 was reported as a limit; the forecaster's own chance of this, stated with the estimate: 10%; middle value at least 1.6-fold (0.22 log units) away from the limit.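

In this assay, compound 3 is reported only as a limit, not as a number: the limit of > 50000 nM in this assay, at which 1 of the 3 values shown sits. Putting 2-ethyl-6-methylphenyl on the aromatic nitrogen in place of 2-ethoxyphenyl gives an at least 1.6-fold higher number from compound 2 to compound 3 (0.21 log units; that floor lies within the scatter), and putting it in place of 2-chlorophenyl gives an at least 1.4-fold higher number from compound 1 to compound 3 (0.17 log units; that floor lies within the scatter). Unlike the earlier pair, these steps have only a floor, so this change shows that the aryl group can take the result out of the measurable range, although both floors lie within the scatter and the true size of each step remains unknown.

The compounds shown leave open how far the real value of compound 3 lies from the other two. They also leave open whether an amine or a carboxylic acid on this aryl group would move the number beyond the scatter.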